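Swapping the aryl group on the pyridazinone nitrogen: cytotoxicity

This account rests on a few compounds, and the source may have more. Where it says the series, first, only, none or still open, it means among the compounds named here.

Compound 1 `CNC(=O)c1cc(Oc2ccc(NC(=O)c3nn(-c4ccc(Br)cc4F)c(=O)cc3C)cc2F)ccn1` and compound 3 `Cc1cc(=O)n(-c2ccc(Br)cc2F)nc1C(=O)Nc1ccc(Oc2ncnc3ccsc23)cc1` share a core but carry different right-hand parts; the difference between the two cores is not broken down here. In a functional assay on A549 cells (Homo sapiens) for cytotoxicity, read by MTT assay, with a stated time of 72 h (a higher number here means a weaker inhibitor, a lower number a stronger inhibitor), compound 1 gives 7930 nM, and compound 3 gives 7930 nM, level with compound 1 within the scatter. Compound 2 `CNC(=O)c1cc(Oc2ccc(NC(=O)c3nn(-c4ccccc4OC(F)(F)F)c(=O)cc3C)cc2F)ccn1` arises from compound 1 by 2-(trifluoromethoxy)phenyl in place of 4-bromo-2-fluorophenyl on an aromatic nitrogen. In this assay compound 2 reaches only a limit of the assay, > 40000 nM. The step is therefore a lower bound, as the limit of > 40000 nM in this assay, at which 1 of the 3 values shown sits, shows, and it amounts to an at least 5.0-fold higher number from compound 1 to compound 2 (0.70 log units; beyond the scatter). Compound 4 `Cc1cc(=O)n(-c2ccccc2OC(F)(F)F)nc1C(=O)Nc1ccc(Oc2ncnc3ccsc23)cc1` is made from compound 3 by the same change, (2-(trifluoromethoxy)phenyl in place of 4-bromo-2-fluorophenyl on an aromatic nitrogen). Resting on the measured step from compound 1 to compound 2 an at least 5.0-fold higher number from compound 1 to compound 2 (0.70 log units; beyond the scatter), compound 4 is expected to show a step of a 5.7-fold higher number from compound 3 to compound 4 (0.75 log units; beyond the scatter) in this assay. Compound 4 is thus estimated at 45000 nM, with a likely range of 18000 nM to 150000 nM, and most probably only a limit will be reported.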

Compound 4, half-maximal inhibitory concentration: 10100 nM
Beside the measured number, compound 4's estimate is 4.5-fold (0.65 log units) above it; the whole stated range lies above it.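

In this assay the same replacement on the core of compound 3 gives a 1.3-fold higher number from compound 3 to compound 4 (0.11 log units; within the scatter), so the size of the step seen on the core of compound 1 did not carry over to this second core. The two steps differ: the same change on two cores in this assay, an at least 5.0-fold higher number (0.70 log units; beyond the scatter) from compound 1 to compound 2 and a 1.3-fold higher number (0.11 log units; within the scatter) from compound 3 to compound 4, at least 3.9-fold (0.59 log units) apart, beyond the scatter of two such steps. Compound 2 sits at a limit of the assay (> 40000 nM), so its step is only a bound, and two cores, which differ in more than one part, do not show which part of them sets the size of the step.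

From the compounds shown here alone, whether a third core would follow compound 2 or compound 4 remains open. So does how a benzyl or a pyridyl group on that aromatic nitrogen would compare on either core.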